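The source may report more compounds than this note shows. Statements on the series, on what has been measured and on what is new or still open speak of the compounds shown alone.

Measured in an ADME assay on a cell-free system (plasma, Homo sapiens); on this read-out lower numbers stand for a smaller free fraction and higher numbers for a larger free fraction:
- Compound 1 `CCCS(=O)(=O)c1cccc(C#Cc2cc(Cl)ccc2OCC(=O)O)c1`: 0.008
- Compound 2 `CCCS(=O)(=O)c1ccc(F)c(C#Cc2cc(Cl)ccc2OCC(=O)O)c1`: 0.01
- Compound 3 `O=C(O)COc1ccc(Cl)cc1C#Cc1cccnc1`: 0.029

In this assay, compound 2 at 0.01 lies within the scatter of compound 1 and clearly under compound 3. Compound 4 `CS(=O)(=O)c1ccc(F)c(C#Cc2cc(Cl)ccc2OCC(=O)O)c1` differs from compound 2 in one place, hydrogen in place of ethyl on a saturated chain carbon bound to a sulfonyl sulfur: propylsulfonyl becomes methylsulfonyl. Among the measured compounds shown here, the only measured step, a 1.3-fold higher number from compound 1 to compound 2 (0.10 log units; within the scatter), is fluoro in place of hydrogen on an aromatic carbon, so it does not test this chain. Compound 3, which has no propylsulfonyl group and differs elsewhere too, gives 0.029, a weak hint of direction. A small rise is therefore expected, an estimated 1.6-fold higher number from compound 2 to compound 4 (0.20 log units; within the scatter). For compound 4 the estimated value is 0.016, with an expected range from 0.009 to 0.03.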

Compound 4, unbound fraction: 0.013
Beside the measured number, compound 4's estimate is 1.2-fold (0.09 log units) above it; low and high end bracket the measured number.
By their numbers in this assay, from the lowest: compounds 1, 2 and 4 (each within the scatter of the next); then compound 3.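

Cutting propylsulfonyl back to methylsulfonyl gives the first direct test of this chain, and in this assay it yields a 1.3-fold higher number from compound 2 to compound 4 (0.11 log units; within the scatter) as the free fraction. Within the scatter, the two compounds cannot be told apart, so removing this ethyl has no readable effect on the free fraction here. Nothing measured here offers an explanation for this result. Going by these compounds, it remains open how an amine or a chain longer than propyl at this place would read. On these data alone, whether the same change would read alike without the fluoro group also remains open.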